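A few compounds are considered here, and "the series" means these few. Any claim that something is new, unique, unknown or untested is made for them only; others in the source may bear on it.

Measured compounds:
Compound 1 `Cc1nn(C)c(-n2cccc2)c1/C=N/OCc1ccc(C(=O)OC(C)(C)C)cc1` gives 2.67 ug/mL in a functional assay on XF498 cells (Homo sapiens) for cytotoxicity; on this read-out lower numbers stand for stronger inhibition and higher numbers for weaker inhibition.
Compound 2 `Cc1nn(C)c(Oc2ccc(Cl)cc2)c1/C=N/OCc1ccc(C(=O)OC(C)(C)C)cc1` gives 0.02 ug/mL in this assay.
Compound 3 `Cc1nn(C)c(N2CCCC2)c1/C=N/OCc1ccc(C(=O)OC(C)(C)C)cc1` gives 0.12 ug/mL in this assay.

Compound 3 stands second highest of the three numbers in this assay. Its nearest neighbour is compound 2, reached by a 6.0-fold higher number from compound 2 to compound 3 (0.78 log units; beyond the scatter), and its furthest is compound 1, from which it is separated by a 22-fold lower number from compound 1 to compound 3 (1.35 log units; beyond the scatter).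

Compound 4 `Cc1nn(C)c(-n2ccnc2)c1/C=N/OCc1ccc(C(=O)OC(C)(C)C)cc1` differs from compound 3 in one place: 1H-imidazol-1-yl in place of pyrrolidin-1-yl on an aromatic carbon. Among the measured compounds shown here, two measured steps bear on this change. The step of a 22-fold lower number from compound 1 to compound 3 (1.35 log units; beyond the scatter) shows that replacing a five-membered aromatic ring on this carbon by pyrrolidin-1-yl lowers the number strongly, and the step of a 130-fold lower number from compound 1 to compound 2 (2.13 log units; beyond the scatter) shows that the same position tolerates a large range. The entering group in compound 4 is again a five-membered aromatic ring, as in compound 1, so the change is expected to run partly back toward compound 1, that is, to a higher number, though the two aromatic rings are not identical and the size of the return is uncertain.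

Compound 4 is therefore expected to give 1 ug/mL in this assay, with a likely range from 0.2 ug/mL to 5 ug/mL.

Compared with compound 3, this estimate means the step of an 8.3-fold higher number from compound 3 to compound 4 (0.92 log units; beyond the scatter) in this assay, a step expected to lie beyond the scatter.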

Compound 4, half-maximal inhibitory concentration: 8.15 ug/mL
For compound 4 the middle estimate is 8.2-fold (0.91 log units) below the measured one; measured number outside the range, above it.
By their numbers in this assay, from the lowest: compound 2; then compound 3; then compound 1; then compound 4.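

In this assay, the 1H-imidazol-1-yl group does not simply reproduce the 1H-pyrrol-1-yl result: a 3.1-fold higher number from compound 1 to compound 4 (0.48 log units; beyond the scatter) shows that these two five-membered aromatic rings are not interchangeable on this aromatic carbon. Among the compounds shown here, the change from the non-aromatic pyrrolidin-1-yl group is larger than the earlier steps suggested, at a 68-fold higher number from compound 3 to compound 4 (1.83 log units; beyond the scatter), and the contrast with 4-chlorophenoxy reaches a 410-fold higher number from compound 2 to compound 4 (2.61 log units; beyond the scatter), so the range of numbers at this position is wider than the first three compounds showed, with the two five-membered aromatic rings giving the two highest numbers of the four. Nothing given here accounts for the difference between the two aromatic rings or for their separation from the other two groups.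

The compounds shown leave open whether a non-aromatic ring with a second hetero atom, such as morpholin-4-yl, or an open-chain amine, such as dimethylamino, would stay near compound 3 or move toward compound 4. They also leave open how much the chlorine of the 4-chlorophenoxy group contributes, a question that an unsubstituted phenoxy group would address.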